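The source may report more compounds than this note shows. Statements on the series, on what has been measured and on what is new or still open speak of the compounds shown alone.

Measured in a functional assay on HepG2 cells (Homo sapiens) for antiproliferative activity, read by MTT assay, with a stated time of 48 h; a higher number here means a weaker inhibitor, a lower number a stronger inhibitor:
- compound 1 `Cc1ccc(-c2nc(NC(=O)c3ccccc3)c3cc(Cl)ccc3n2)cc1`: 17.5 ug/mL
- compound 2 `CSc1nc(-c2ccc(C)cc2)nc2ccc(Cl)cc12`: 13.3 ug/mL

Compound 2 and compound 1 lie within the scatter of each other, so compound 2 holds no clear place in this pair. Next comes compound 3 `Cc1ccc(-c2nc(Sc3ncccc3[N+](=O)[O-])c3cc(Cl)ccc3n2)cc1`, with 3-nitropyridin-2-yl in place of methyl on a sulfur. Within the data shown here, the one measured step that bears on it is a 1.3-fold lower number from compound 1 to compound 2 (0.12 log units; within the scatter), which is methylsulfanyl in place of benzamido on an aromatic carbon. It touches the same point of the core but does not test a change on the sulfur. Among the measured compounds shown here, no measured compound carries anything other than methyl on this sulfur, so the exchange itself has no direct precedent. For the measured compounds named here, with a 1.3-fold lower number from compound 1 to compound 2 (0.12 log units; within the scatter) as the only guide, no shift beyond the scatter is expected in this assay, and no direction is favoured. The expected step is a 1.1-fold lower number from compound 2 to compound 3 (0.04 log units; within the scatter). For compound 3 the estimated value is 12 ug/mL, with an expected range from 5 ug/mL to 30 ug/mL.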

Compound 3, half-maximal inhibitory concentration: 5.59 ug/mL
Compound 3: the middle estimate sits 2.1-fold (0.33 log units) above what was measured, within the range that was stated.
By their numbers in this assay, from the lowest: compound 3; then compounds 2 and 1 (each within the scatter of the next).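

In this assay, 3-nitropyridin-2-yl in place of methyl on a sulfur gives a 2.4-fold lower number from compound 2 to compound 3 (0.38 log units; beyond the scatter), a modest step but the only one so far that lies beyond the scatter. Among these compounds, this is also the first direct reading on the sulfur substituent, since the earlier step replaced the whole benzamido group with methylsulfanyl and left open what a change on the sulfur itself would do. The sulfur accepts a much larger aromatic group than methyl without a rise in the number, and the number instead moves down, although no data shown here help explain this step.

The step changes several things at once, so the ring, its ring nitrogen and the nitro group cannot be told apart: plain phenyl or unsubstituted pyridin-2-yl on the sulfur would separate them, as would an amine or a nitrile in place of the nitro group. From the compounds shown here alone, the role of the sulfur link also remains open, and the same 3-nitropyridin-2-yl attached through an ether oxygen or an amine nitrogen would address it.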